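The source may hold more compounds than are shown below. What is called first, only, known or untested is meant among the compounds shown, and "the series" means these compounds.

Measured so far:
compound 1 `O=C(c1ccc(Cl)cc1)N1CCC(NS(=O)(=O)c2cc(S(=O)(=O)c3ccccc3)ccc2C(F)(F)F)CC1` gives 1800 nM
compound 2 `O=C(c1ccc(C(F)(F)F)cc1)N1CCC(NS(=O)(=O)c2cc(S(=O)(=O)c3ccccc3)ccc2C(F)(F)F)CC1` gives 970 nM
compound 3 `CN(C)c1ccc(C(=O)N2CCC(NS(=O)(=O)c3cc(S(=O)(=O)c4ccccc4)ccc3C(F)(F)F)CC2)cn1` gives 70 nM

All three numbers come from an assay on U2OS cells for inhibition of secreted frizzled-related protein 1 (Homo sapiens), read by a luciferase reporter, with a stated time of 18 h; a higher number here means that more compound is needed for the effect, a lower number that less compound is needed. Compound 3 stands lowest of the three: the steps of a 26-fold lower number from compound 1 to compound 3 (1.41 log units; beyond the scatter) and a 14-fold lower number from compound 2 to compound 3 (1.14 log units; beyond the scatter) are both large, whereas a 1.9-fold lower number from compound 1 to compound 2 (0.27 log units; within the scatter) is not. Compound 4 `CC(C)(O)CCN1CCC(NS(=O)(=O)c2cc(S(=O)(=O)c3ccccc3)ccc2C(F)(F)F)CC1` differs from compound 3 by 3-hydroxy-3-methylbutyl in place of (6-(dimethylamino)pyridin-3-yl)carbonyl on an amine nitrogen in a ring. Going by the values given here, no measured step removes the carbonyl itself, so the two large steps bear on this change only indirectly: they show that exchanging the group on that carbonyl shifts the number strongly. A shift of comparable size is therefore expected here, with the direction uncertain but more likely toward a higher number, since the best group seen is the one that leaves. Compound 4 is expected to give 1500 nM, in the range 300 nM to 8000 nM, which means an expected step of a 21-fold higher number from compound 3 to compound 4 (1.33 log units; beyond the scatter).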

Compound 4, half-maximal effective concentration: 630 nM
Beside the measured number, compound 4's estimate is 2.4-fold (0.38 log units) above it; the range from low to high includes it.
By their numbers in this assay, from the lowest: compound 3; then compounds 4, 2 and 1 (each within the scatter of the next, the first and the last beyond it).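

Compound 4 shows that the ring nitrogen can carry a chain with no carbonyl and no ring and still stay in the range of the two benzoyl compounds: a 1.5-fold lower number from compound 2 to compound 4 (0.19 log units; within the scatter), and a 2.9-fold lower number from compound 1 to compound 4 (0.46 log units; beyond the scatter). The low number of compound 3 is not reached, however: a 9.0-fold higher number from compound 3 to compound 4 (0.95 log units; beyond the scatter). Nothing measured here explains these differences. Still open, going by these compounds, is whether compound 3 owes its low number to the carbonyl or to the pyridine ring, which a (6-(dimethylamino)pyridin-3-yl)methyl group on the same nitrogen would separate. Also open, on these data alone, is what the hydroxyl of compound 4 contributes, which a plain 3-methylbutyl chain would test.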